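This account rests on a few compounds, and the source may have more. Where it says the series, first, only, none or still open, it means among the compounds named here.

Compound 1, `Cc1cnc(Nc2ccc(C#N)cc2)nc1Nc1c(F)cc(-c2cc(F)nc(F)c2)cc1F`, gives 103000 nM in a toxicity assay on MT4 cells (Homo sapiens) for cytotoxicity, read by MTT assay, with a stated time of 5 days; a higher number here means that more compound is tolerated, a lower number that less compound is tolerated.
Compound 2, `Cc1cnc(Nc2ccc(C#N)cc2)nc1Nc1c(F)cc(-c2cncc(C(F)(F)F)c2)cc1F`, gives 8200 nM.
Compound 3, `Cc1cc(-c2ccnc3ccccc23)cc(C)c1Nc1ccnc(Nc2ccc(C#N)cc2)n1`, gives 3500 nM.

Compound 3 stands lowest of the three numbers, so it is the least tolerated; its gaps to compound 1 and compound 2 are both beyond the scatter. Compound 4, `Cc1cc(-c2cnc(C(F)(F)F)nc2)cc(C)c1Nc1ccnc(Nc2ccc(C#N)cc2)n1`, differs from compound 3 in one place: 2-(trifluoromethyl)pyrimidin-5-yl in place of quinolin-4-yl on an aromatic carbon. Among the compounds with values here, only one measured step brings in a group carrying trifluoromethyl, a 13-fold lower number from compound 1 to compound 2 (1.10 log units; beyond the scatter), and there the number fell; that step sits on a different core and a different pair of groups, so it bears only loosely here. Compound 2, which also carries trifluoromethyl, gives a higher number than compound 3. The expected step of a 1.4-fold higher number from compound 3 to compound 4 (0.15 log units; within the scatter) is therefore small, within the scatter. Compound 4 is expected to give 5000 nM, between 1500 nM and 20000 nM.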

Compound 4, half-maximal cytotoxic concentration: 4900 nM
Compound 4: the middle estimate sits 1.0-fold (0.01 log units) above what was measured, within the range that was stated.
By their numbers in this assay, from the lowest: compounds 3, 4 and 2 (each within the scatter of the next, the first and the last beyond it); then compound 1.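

In this assay, the step of a 1.4-fold higher number from compound 3 to compound 4 (0.15 log units; within the scatter) shows that 2-(trifluoromethyl)pyrimidin-5-yl can take the place of quinolin-4-yl at this aromatic carbon, meta to two methyl groups, with a difference that stays within the scatter. The earlier step of a 13-fold lower number from compound 1 to compound 2 (1.10 log units; beyond the scatter) was large, so bringing in a group that carries trifluoromethyl does not go with a large drop in both pairs, although the two pairs differ in core and in the group that leaves. Nothing measured here explains this result. Still open, going by these compounds, is whether an amine or a carboxylic acid at this position would move the number beyond the scatter. Also open, on these data alone, is how 2-(trifluoromethyl)pyrimidin-5-yl would behave on the core of compound 1.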